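This account rests on a few compounds, and the source may have more. Where it says the series, first, only, none or still open, it means among the compounds named here.

The measured compounds:

compound 1, `O=C(/C=C/c1ccncc1-c1ccc2cc[nH]c2c1)N1CCOCC1`, gives 43.9 nM
compound 2, `Cn1ccc2cc(-c3cnccc3/C=C/C(=O)N3CCOCC3)ccc21`, gives 247 nM
compound 3, `Cn1ccc2cc(-c3cnccc3/C=C/C(=O)O)ccc21`, gives 26.8 nM

All three were tested in an assay on a protein complex for inhibition of CDK8/Cyclin C (Homo sapiens), with a stated time of 1 h; on this read-out lower numbers stand for stronger inhibition and higher numbers for weaker inhibition. Compound 2 and compound 3 share one core and differ in a single place:

hydroxy in place of morpholin-4-yl on a carbonyl carbon

That change produced a 9.2-fold lower number from compound 2 to compound 3 (0.96 log units; beyond the scatter). Compound 1 carries the same morpholin-4-yl amide as compound 2 but on a different core; the difference between the two cores is not broken down here. In this assay compound 1 and compound 3 lie within the usual scatter of each other, while compound 2 stands beyond the scatter from both.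

Compound 4, `O=C(O)/C=C/c1ccncc1-c1ccc2cc[nH]c2c1`, has not yet been measured. It differs from compound 1 in one place:

hydroxy in place of morpholin-4-yl on a carbonyl carbon

The place line reads the same as for the pair of compound 2 and compound 3, so this is the same change, made on the core of compound 1 instead. The step from compound 1 to compound 4 is expected to be of a similar size, a 6.3-fold lower number from compound 1 to compound 4 (0.80 log units; beyond the scatter), because the same change gave a 9.2-fold lower number from compound 2 to compound 3 (0.96 log units; beyond the scatter). This expectation rests on a single measured pair, and the two cores have not been compared under the same change before, so the range is kept wide. Compound 4 is therefore estimated at 7 nM in this assay, expected to fall between 2.5 nM and 25 nM.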

Compound 4, half-maximal inhibitory concentration: 2.4 nM
For compound 4 the middle estimate is 2.9-fold (0.46 log units) above the measured one; measured number outside the range, below it.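

In this assay, putting hydroxy in place of morpholin-4-yl on the carbonyl carbon of compound 1 gave an 18-fold lower number from compound 1 to compound 4 (1.26 log units; beyond the scatter). Going by these compounds alone, on the core of compound 1 the change therefore ran in the same direction as on the core of compound 2, and the two steps cannot be told apart in size: the same change on two cores in this assay, a 9.2-fold lower number (0.96 log units; beyond the scatter) from compound 2 to compound 3 and an 18-fold lower number (1.26 log units; beyond the scatter) from compound 1 to compound 4, 2.0-fold (0.30 log units) apart, within the scatter of two such steps This shows that, on these two cores, the change from (morpholin-4-yl)carbonyl to carboxy carried over from one core to the other, but with only one measured pair on each core, it does not show that the step would hold on any further core, nor does it explain why the number falls.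

The compounds shown leave open whether a primary amide, a dimethylamine amide or a methyl ester on the same carbonyl carbon would read like the morpholin-4-yl amides or like the carboxylic acids. They also leave open whether the carboxy group would give a similar step if a saturated chain took the place of the double-bonded chain carbons that carry it.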